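Replacing the Thiophene Ring with a Methylpyrazole

The source may hold more compounds than are shown below. What is called first, only, known or untested is meant among the compounds shown, and "the series" means these compounds.

Of the compounds shown here, two have been measured so far. Compound 1 `CCCCCCCCCCCC[C@@H](O)[C@H]1CC[C@H]([C@H](O)CCCCCCCCCCNC(=O)c2cncs2)O1` and compound 2 `CCCCCCCCCCCC[C@@H](O)[C@H]1CC[C@H]([C@H](O)CCCCCCCCCCNC(=O)c2ccsc2)O1` share the same long chain and differ only in the ring attached to the carbonyl carbon of the amide. In a functional assay on NCI-H460 cells (Homo sapiens) for inhibition, read by colorimetric assay and sulforhodamine B assay, with a stated time of 48 h (on this read-out higher numbers stand for weaker inhibition of growth and lower numbers for stronger inhibition of growth), compound 1 gives 34700 nM, while compound 2 gives 4900 nM. Within the data shown here, the single measured step, a 7.1-fold lower number from compound 1 to compound 2 (0.85 log units; beyond the scatter), links the thiophen-3-yl ring to the lower number. Among the measured compounds shown here, compound 2 therefore stands at the lower of the two numbers, with compound 1 as its only point of comparison.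

Compound 3 `CCCCCCCCCCCC[C@@H](O)[C@H]1CC[C@H]([C@H](O)CCCCCCCCCCNC(=O)c2ccnn2C)O1` is the next variation: 1-methyl-1H-pyrazol-5-yl in place of thiophen-3-yl on a carbonyl carbon. For the measured compounds named here, no step to a 1-methyl-1H-pyrazol-5-yl ring has been measured, so the only guide is the step in which a five-membered ring with two hetero atoms gave way to one with a single hetero atom and the number fell. Compound 3 returns to a ring with two hetero atoms, so a higher number than that of compound 2 is expected, though not necessarily as large a move as the measured step. The expected change is a 3.1-fold higher number from compound 2 to compound 3 (0.49 log units; beyond the scatter). Compound 3 is estimated at 15000 nM, within a range from 5000 nM to 45000 nM.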

Compound 3, concentration for 50% growth inhibition: 8130 nM
The estimate for compound 3 lay 1.8-fold (0.27 log units) above the measured number, and the stated range covers the measured number.
By their numbers in this assay, from the lowest: compounds 2 and 3 (each within the scatter of the next); then compound 1.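

In this assay, placing 1-methyl-1H-pyrazol-5-yl on the carbonyl carbon gives a 1.7-fold higher number from compound 2 to compound 3 (0.22 log units; within the scatter) and so stays within the usual scatter, which means this assay does not separate these two rings. The other comparison, a 4.3-fold lower number from compound 1 to compound 3 (0.63 log units; beyond the scatter) and beyond the scatter, shows that the count of hetero atoms in the ring does not set the number on its own: the rings of compound 1 and compound 3 each hold two hetero atoms, yet only compound 3 falls within the scatter of compound 2, whose ring holds one. The data offer no measurement that accounts for the gap between the two rings with two hetero atoms.

Among these compounds, with only three rings compared on the same long chain, it remains open whether a six-membered ring such as phenyl or pyridine would also fit at this carbonyl carbon, and whether the pyrazole needs its methyl group. Going by these compounds, it also remains open how the number would respond to a shorter chain between the amide nitrogen and the shared core.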